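A Methoxy Swap on a Bromo Compound

The source may report more compounds than this note shows. Statements on the series, on what has been measured and on what is new or still open speak of the compounds shown alone.

Measured in a functional assay on P388 cells (Mus musculus) for inhibition; on this read-out lower numbers stand for stronger inhibition and higher numbers for weaker inhibition:
- Compound 1 `O=C1/C(=C/c2ccc(Br)cc2)CCc2ccccc21` gives 20400 nM
- Compound 2 `O=C1/C(=C/c2ccc(Cl)cc2)CCCc2ccccc21` gives 9500 nM
- Compound 3 `O=C1/C(=C/c2ccc(Br)cc2)CCCc2ccccc21` gives 18600 nM

On these numbers, compound 3 (18600 nM) lies within the usual scatter of both compound 1 and compound 2. Compound 4 (`COc1ccc(/C=C2\CCCc3ccccc3C2=O)cc1`) has methoxy in place of bromo on an aromatic carbon. Going by the values given here, the one measured step at this place is small (a 2.0-fold higher number from compound 2 to compound 3 (0.29 log units; within the scatter)) and lies within the scatter. Among the compounds with values here, it swaps chloro for bromo, so no measurement yet shows what methoxy does here. With so little to go on, a step within the scatter is expected in this assay (a 1.3-fold lower number from compound 3 to compound 4 (0.12 log units; within the scatter)). Compound 4 is therefore estimated at 14000 nM (expected range 5000 nM to 35000 nM).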

Compound 4, half-maximal inhibitory concentration: 1600 nM
Estimate against measurement, compound 4: 8.8-fold (0.94 log units) above, outside the stated range (below it).
By their numbers in this assay, from the lowest: compound 4; then compounds 2, 3 and 1 (each within the scatter of the next, the first and the last beyond it).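

In this assay this position turns out to be sensitive to the group it carries: the chloro and bromo compounds sit within the scatter of each other, yet methoxy gives a 12-fold lower number from compound 3 to compound 4 (1.07 log units; beyond the scatter) and a 5.9-fold lower number from compound 2 to compound 4 (0.77 log units; beyond the scatter). Changing the type of group here can therefore move the number far more than swapping one halogen for the other. No evidence is available to explain this difference.

As far as these compounds go, whether other groups here, such as a hydroxyl, an amine or ethoxy, would behave like methoxy remains open. So does whether methoxy would have the same effect on the core of compound 1.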